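Carboxylic acid side chains on the pyridyl styryl series

This account rests on a few compounds, and the source may have more. Where it says the series, first, only, none or still open, it means among the compounds named here.

Compound 3 `COCC(CCC/C=C(\c1ccccc1)c1cccnc1)C(=O)O` gives the lowest number of the three measured in an assay (Equus caballus) for inhibition of Thromboxane-A synthase (Homo sapiens), using microsomes (a lower number here means a stronger inhibitor, a higher number a weaker inhibitor), at 41 nM. Compound 2 `CC(C)(O)C(CCC/C=C(\c1ccccc1)c1cccnc1)C(=O)O` stands within the scatter of it, with 42 nM, and a 1.0-fold lower number from compound 2 to compound 3 (0.01 log units; within the scatter). Compound 1 `NC(=O)CCCC/C=C(\c1ccccc1)c1cccnc1`, the carbamoylmethyl analogue, gives 400 nM and sits furthest off: a 9.8-fold lower number from compound 1 to compound 3 (0.99 log units; beyond the scatter), and a 9.5-fold lower number from compound 1 to compound 2 (0.98 log units; beyond the scatter).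

Compound 4 `CC(C)(CCCC/C=C(\c1ccccc1)c1cccnc1)C(=O)O` is unmeasured. The change from compound 3 is 2-carboxy-2-methylpropyl in place of 1-carboxy-2-methoxyethyl on a saturated chain carbon, three bonds along the chain from a double-bonded chain carbon. The carboxylic acid is kept; what goes is the methoxy oxygen, one hydrogen-bond acceptor in the count. The step from compound 1 to compound 2 and the step from compound 1 to compound 3 both point to the carboxylic acid as the part that brought the number down, while the step from compound 2 to compound 3 shows that exchanging the oxygen-bearing group beside the acid moved nothing beyond the scatter. Among the measured compounds shown here, no measured pair removes that oxygen altogether, so some weakening cannot be excluded. Compound 4 is therefore expected to stay close to compound 3 in this assay, with a step of a 1.5-fold higher number from compound 3 to compound 4 (0.17 log units; within the scatter) anticipated. The estimate for compound 4 is 60 nM, in a range from 25 nM to 150 nM.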

Compound 4, half-maximal inhibitory concentration: 45 nM
Estimate against measurement, compound 4: 1.3-fold (0.12 log units) above; measured number inside the range.
By their numbers in this assay, from the lowest: compounds 3, 2 and 4 (each within the scatter of the next); then compound 1.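

In this assay, taking out the methoxy oxygen leaves no mark on the number: a 1.1-fold higher number from compound 3 to compound 4 (0.04 log units; within the scatter), and a 1.1-fold higher number from compound 2 to compound 4 (0.03 log units; within the scatter), so 2-carboxy-2-methylpropyl, with its single hydrogen-bond acceptor, reads the same as the two oxygen-bearing side chains. The separation from the amide also survives without that extra oxygen, with an 8.9-fold lower number from compound 1 to compound 4 (0.95 log units; beyond the scatter), so all three carboxylic acid compounds now stand beyond the scatter of compound 1, and an oxygen on the chain outside the acid is not needed for that separation. No supporting data on the compounds accounts for this flat reading among the acids.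

The compounds shown leave open whether a tetrazole or a sulfonic acid could stand in for the carboxylic acid at this place. They also leave open how a longer chain between the double-bonded chain carbon and the acid would read.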